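Changing a Ring Substituent Before the Clearance Is Known

The compounds below may be only part of what the source reports. "The series", "measured", "known", "first", "only" and "open" are said of these compounds alone.

Compound 2, `CNCc1cc(N2CCCS2(=O)=O)ccc1Oc1ccc(Cl)cc1Cl`, was run in an in vitro ADME assay on microsomes from liver (Homo sapiens) for metabolic stability (a lower number here means slower removal, a higher number faster removal of the compound), and gives 12 mL.min-1.g-1. Among the measured compounds shown here, the only other compound with a result, compound 1, `CNCc1ccccc1Oc1ccc(Cl)cc1F`, gives 22 mL.min-1.g-1 in this assay. Compound 2 therefore holds the lowest of the two numbers, but its gap to compound 1 falls within the usual scatter of repeat measurements, so the two values cannot be separated with confidence.

Compound 3, `CNCc1cc(C(=O)N(C)C)ccc1Oc1ccc(Cl)cc1Cl`, is still waiting for its turn in this assay. It differs from compound 2 in a single place: a group of 5 heavy atoms (3 carbon, 1 nitrogen, 1 oxygen; no ring) in place of a group of 7 heavy atoms (3 carbon, 1 nitrogen, 2 oxygen, 1 sulfur; one five-membered non-aromatic ring with 2 hetero atoms), on an aromatic carbon. For the measured compounds named here, no pair of measured compounds shows what this particular exchange does to clearance, so the expectation rests only on the two values already in hand and on the fact that the rest of the molecule stays the same. The expected step is a 1.3-fold higher number from compound 2 to compound 3 (0.10 log units; within the scatter), small enough to sit inside the scatter, with a slight lean towards a higher number. For compound 3 the estimate in this assay is 15 mL.min-1.g-1, with a plausible range from 7 mL.min-1.g-1 to 35 mL.min-1.g-1.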

Compound 3, intrinsic clearance in microsomes: 13 mL.min-1.g-1
For compound 3 the middle estimate is 1.2-fold (0.06 log units) above the measured one; the measured number falls inside the stated range.
By their numbers in this assay, from the lowest: compounds 2, 3 and 1 (each within the scatter of the next).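

On the aromatic carbon that is meta to the (methylamino)methyl group, replacing the five-membered ring containing sulfur with dimethylcarbamoyl gives, in this assay, a 1.1-fold higher number from compound 2 to compound 3 (0.03 log units; within the scatter) and so leaves the two compounds indistinguishable. Among the compounds shown here, this is the first pair of measured compounds that differ in only one place, which gives this position its first direct reading: in this read-out, a group with no ring and fewer heavy atoms stands in for the larger ring-bearing group without a change that can be separated from the scatter. Nothing measured here offers an explanation for why the two groups read so much alike.

A single exchange cannot show how far this tolerance extends, and a primary amine or a carboxylic acid on the same aromatic carbon could give a quite different number from the two groups compared here. From the compounds shown here alone, it also remains open whether dimethylcarbamoyl would read the same way on the core of compound 1, which carries a different halogen pattern on its other ring.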